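Trifluoromethyl in place of fluoro in compound 3

This account rests on a few compounds, and the source may have more. Where it says the series, first, only, none or still open, it means among the compounds named here.

In a functional assay on HeLa cells (Homo sapiens) for antiproliferative activity, read by MTT assay, with a stated time of 24 h (on this read-out higher numbers stand for weaker inhibition and lower numbers for stronger inhibition), compound 3 (`O=S(=O)(c1ccc(F)cc1)n1c(-c2cn(-c3ccccc3)nc2-c2ccc(C(F)(F)F)cc2)nc2ccccc21`) gives 2190 nM and stands level, within the scatter, with compound 1 (`Cc1ccc(-c2nn(-c3ccccc3)cc2-c2nc3ccccc3n2S(=O)(=O)c2ccc(C(F)(F)F)cc2)cc1`) at 1520 nM while lying on the weaker side of compound 2 (`COc1ccc(S(=O)(=O)n2c(-c3cn(-c4ccccc4)nc3-c3ccc(C(F)(F)F)cc3)nc3ccccc32)cc1`) at 250 nM by a margin beyond the scatter. Compound 4 (`O=S(=O)(c1ccc(C(F)(F)F)cc1)n1c(-c2cn(-c3ccccc3)nc2-c2ccc(C(F)(F)F)cc2)nc2ccccc21`) carries trifluoromethyl in place of fluoro on an aromatic carbon para to a large group. For the measured compounds named here, the one measured step on that carbon is an 8.8-fold higher number from compound 2 to compound 3 (0.94 log units; beyond the scatter) and it is modest, but it exchanges methoxy rather than trifluoromethyl. Compound 1 also carries 4-(trifluoromethyl)phenyl, with another difference elsewhere, and its 1520 nM sits within the scatter of compound 3. The expected size is a 1.5-fold lower number from compound 3 to compound 4 (0.16 log units; within the scatter) and thus no change beyond the scatter in this assay for this swap. Compound 4 is estimated at 1500 nM (range 500 nM to 4500 nM).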

Compound 4, half-maximal inhibitory concentration: 970 nM
Compound 4: middle estimate off by 1.5-fold (0.19 log units), on the high side; low and high end bracket the measured number.
By their numbers in this assay, from the lowest: compound 2; then compounds 4, 1 and 3 (each within the scatter of the next, the first and the last beyond it).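

In this assay, the exchange of fluoro for trifluoromethyl on this carbon gives a 2.3-fold lower number from compound 3 to compound 4 (0.35 log units; beyond the scatter), so this position separates these two groups beyond the scatter. Methoxy on the same carbon still keeps the lower number, with a 3.9-fold higher number from compound 2 to compound 4 (0.59 log units; beyond the scatter). Trifluoromethyl in place of methyl gives a 1.6-fold lower number from compound 1 to compound 4 (0.20 log units; within the scatter), which leaves that pair level. Nothing at hand explains these steps. The compounds shown leave open how an amine or a carboxylic acid on this carbon would compare, and whether the order of methoxy, trifluoromethyl and fluoro holds in other cells.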